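Swapping 4-methylphenyl for cyclohexyl on an amide-type nitrogen

The source may hold more compounds than are shown below. What is called first, only, known or untested is meant among the compounds shown, and "the series" means these compounds.

Measured compounds in a functional assay on A549 cells (Homo sapiens) for antiproliferative activity, read by MTT assay, with a stated time of 72 h (a higher number here means a weaker inhibitor, a lower number a stronger inhibitor), and their values
compound 1 `COc1ncc(-c2ccc3c(c2)N(c2ccc(C)cc2)C(=O)CO3)cc1NS(=O)(=O)c1ccc(F)cc1` gives 5870 nM
compound 2 `O=C1COc2ccc(-c3cccc(NS(=O)(=O)c4ccc(F)cc4)c3)cc2N1` gives 32100 nM

Of these two numbers, compound 1 holds the lower one, and compound 2 sits higher by a gap beyond the usual scatter. The two compounds differ in more than one place, so that gap does not isolate any single change.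

The next compound is compound 3 (`COc1ncc(-c2ccc3c(c2)N(C2CCCCC2)C(=O)CO3)cc1NS(=O)(=O)c1ccc(F)cc1`), which keeps the core of compound 1 and changes one group: cyclohexyl in place of 4-methylphenyl on an amide-type nitrogen in a ring. This puts cyclohexyl in place of 4-methylphenyl on an amide-type nitrogen in a ring. For the measured compounds named here, no measured pair shows this change directly. Going by the values given here, compound 1, at 5870 nM, is the only measured compound with 4-methylphenyl there, so it anchors the expectation. In this assay the expected step is small, toward a slightly higher number, and none beyond the scatter is expected. The estimated change is a 1.4-fold higher number from compound 1 to compound 3 (0.13 log units; within the scatter) in size. Compound 3 is expected at 8000 nM (2500 nM to 25000 nM).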

Compound 3, half-maximal inhibitory concentration: 24600 nM
Beside the measured number, compound 3's estimate is 3.1-fold (0.49 log units) below it, and the stated range covers the measured number.
By their numbers in this assay, from the lowest: compound 1; then compounds 3 and 2 (each within the scatter of the next).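

Putting cyclohexyl in place of 4-methylphenyl on the amide-type nitrogen in a ring gives a 4.2-fold higher number from compound 1 to compound 3 (0.62 log units; beyond the scatter) in this assay. For the compounds shown here, this is the first comparison that isolates a single change, and it shows that the read-out responds to the group at this position, with the step lying beyond the scatter. Of the two groups tested here, the one with a six-membered aromatic ring of carbon only goes with the lower number, while the one with a six-membered non-aromatic ring of carbon only goes with the higher number, and no measurement available here accounts for that difference.

The compounds shown leave open how other groups on this nitrogen would read, such as a small methyl, a benzyl or a chain ending in an amine, and whether the aromatic ring itself or its 4-methyl group matters more. On these data alone, the finding also rests on one pair of compounds, so it remains unknown whether the same swap would shift the number in the same direction on a different core.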